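The source may report more compounds than this note shows. Statements on the series, on what has been measured and on what is new or still open speak of the compounds shown alone.

Measured so far in an ADME assay on Caco-2 cells (Homo sapiens) for permeability, in the apical to basolateral direction; on this read-out lower numbers stand for lower permeability and higher numbers for higher permeability:
compound 1, `Cn1cncc1CN1CC(N(CC2CCN(C(=O)NC(C)(C)C)CC2)S(=O)(=O)c2ccccn2)Cc2cc(C#N)ccc21`: 0.6 10^-6 cm/s
compound 2, `CCS(=O)(=O)N1CCC(CN(C2Cc3cc(C#N)ccc3N(Cc3cncn3C)C2)S(=O)(=O)c2ccccn2)CC1`: 0.1 10^-6 cm/s

Going by the values given here, compound 1 stands highest of the two numbers in this assay; the only measured step, a 6.0-fold lower number from compound 1 to compound 2 (0.78 log units; beyond the scatter), replaces the whole carbamoyl by ethylsulfonyl. Compound 3, `CC(C)NC(=O)N1CCC(CN(C2Cc3cc(C#N)ccc3N(Cc3cncn3C)C2)S(=O)(=O)c2ccccn2)CC1`, differs from compound 1 by hydrogen in place of methyl on a saturated chain carbon bound to an amide-type nitrogen and two saturated chain carbons. Among the compounds with values here, no measured step matches this change; the step to compound 2 bears on it only loosely, and its direction need not carry over to trimming one methyl. A step within the scatter is therefore expected in this assay, if anything slightly downward. Compound 3 is estimated at 0.5 10^-6 cm/s, range 0.2 10^-6 cm/s to 1.2 10^-6 cm/s, meaning an expected step of a 1.2-fold lower number from compound 1 to compound 3 (0.08 log units; within the scatter).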

Compound 3, apparent permeability: 0.6 10^-6 cm/s
Beside the measured number, compound 3's estimate is 1.2-fold (0.08 log units) below it; measured number inside the range.
By their numbers in this assay, from the lowest: compound 2; then compounds 1 and 3 (each within the scatter of the next).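

In this assay, tert-butyl to isopropyl gives no change at the digits printed from compound 1 to compound 3 (within the scatter), so losing this one methyl from the carbamoyl group leaves the read-out unmoved. Ethylsulfonyl to isopropylcarbamoyl gives a 6.0-fold higher number from compound 2 to compound 3 (0.78 log units; beyond the scatter), so the gap between the ethylsulfonyl compound and a carbamoyl compound now holds for two different carbamoyl groups, not just (tert-butyl)carbamoyl. Nothing available gives a reason for either step.
Still open, going by these compounds, is whether a cyclopropyl group, a longer chain or an amine in place of the isopropyl would shift the read-out, and whether methylsulfonyl would behave like ethylsulfonyl.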